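Removing the Ethenyl Link from Compound 3

The compounds below may be only part of what the source reports. "The series", "measured", "known", "first", "only" and "open" are said of these compounds alone.

In a functional assay on PC-3 cells (Homo sapiens) for inhibition, read by sulforhodamine B assay, with a stated time of 48 h (on this read-out lower numbers stand for stronger inhibition and higher numbers for weaker inhibition), compound 3 (`O=C(/C=C/c1ccc(CN2CCc3cc(NC(=O)Nc4ccc(Cl)c(C(F)(F)F)c4)ccc32)cc1)NO`) gives 2300 nM and lies within the usual scatter of compound 1 (`O=C(Nc1ccc2c(c1)N(Cc1ccc(C(=O)NO)cc1)CC2)Nc1ccc(Cl)c(C(F)(F)F)c1`) at 3100 nM and of compound 2 (`O=C(Nc1ccc2c(c1)CCN2c1ccc(C(=O)NO)cc1)Nc1ccc(Cl)c(C(F)(F)F)c1`) at 3800 nM without standing apart from either. Compound 4 (`O=C(Nc1ccc2c(c1)CCN2Cc1ccc(C(=O)NO)cc1)Nc1ccc(Cl)c(C(F)(F)F)c1`) has hydroxycarbamoyl in place of 2-(hydroxycarbamoyl)ethenyl on an aromatic carbon, para to a large group (hydroxycarbamoyl in place of 2-(hydroxycarbamoyl)ethenyl on an aromatic carbon). For the measured compounds named here, no measured pair isolates this change. Still, compound 1 also carries hydroxycarbamoyl and gives 3100 nM within the scatter of compound 3, so no step beyond the scatter is expected in this assay for this change. The estimated 1.3-fold higher number from compound 3 to compound 4 (0.12 log units; within the scatter) stays that small. Compound 4 is expected at 3000 nM with an estimated range from 1300 nM to 7000 nM in this test.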

Compound 4, half-maximal inhibitory concentration: 3400 nM
The estimate for compound 4 lay 1.1-fold (0.05 log units) below the measured number; low and high end bracket the measured number.
By their numbers in this assay, from the lowest: compounds 3, 1, 4 and 2 (each within the scatter of the next).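

For the compounds shown here, the first measured pair for this change shows that, in this assay, hydroxycarbamoyl in place of 2-(hydroxycarbamoyl)ethenyl on the aromatic carbon gives no step beyond the scatter (a 1.5-fold higher number from compound 3 to compound 4 (0.17 log units; within the scatter)). On the nitrogen of the shared core, 4-(hydroxycarbamoyl)benzyl in place of 4-(hydroxycarbamoyl)phenyl likewise stays within the scatter (a 1.1-fold lower number from compound 2 to compound 4 (0.05 log units; within the scatter)). No available evidence bears on these results.

As far as these compounds go, whether a carboxylic acid or an amine at this aromatic carbon would stay within the same scatter remains open. So does the effect of a longer chain carrying the hydroxycarbamoyl group.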